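This account rests on a few compounds, and the source may have more. Where it says the series, first, only, none or still open, it means among the compounds named here.

In a functional assay on HL-60 cells (Homo sapiens) for cytotoxicity, read by MTT assay, with a stated time of 72 h (on this read-out lower numbers stand for stronger inhibition and higher numbers for weaker inhibition), compound 1 `Clc1ccccc1-c1nnc2nnc(N3CCCC3)nn12` gives 2660 nM. Compound 2 `CC(C)(C)c1nnc2nnc(N3CCCC3)nn12` sits at the assay limit (the limit of > 100000 nM in this assay, at which 1 of the 3 values shown sits), recorded as > 100000 nM, which is a limit and not a number. Compound 3 `CCc1nnc2nnc(N3CCCC3)nn12` gives 47000 nM, the highest number among the measured compounds, seen in an 18-fold higher number from compound 1 to compound 3 (1.25 log units; beyond the scatter) and in an at least 2.1-fold lower number from compound 2 to compound 3 (0.32 log units; beyond the scatter). Compound 4 `CCCCCc1nnc2nnc(N3CCCC3)nn12` differs from compound 3 by propyl in place of hydrogen on a saturated chain carbon, two bonds along the chain from an aromatic carbon. Within the data shown here, the measured steps show that 2-chlorophenyl on the core does far better than ethyl, while tert-butyl does worse, and a longer straight chain has no direct precedent here. Only a modest shift is therefore expected, with a 1.9-fold lower number from compound 3 to compound 4 (0.27 log units; within the scatter). Compound 4 is estimated at 25000 nM, within 6000 nM to 100000 nM.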

Compound 4, half-maximal inhibitory concentration: 42500 nM
Compound 4: middle estimate off by 1.7-fold (0.23 log units), on the low side, within the range that was stated.
By their numbers in this assay, from the lowest: compound 1; then compounds 4 and 3 (each within the scatter of the next). At a limit, above all of these: compound 2.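

In this assay, adding propyl to the ethyl chain gives a 1.1-fold lower number from compound 3 to compound 4 (0.04 log units; within the scatter), so ethyl and pentyl on the shared core cannot be told apart here. The longer straight chain also leaves a wide gap to the 2-chlorophenyl group, with a 16-fold higher number from compound 1 to compound 4 (1.20 log units; beyond the scatter). Against tert-butyl there is an at least 2.3-fold lower number from compound 2 to compound 4 (0.37 log units; beyond the scatter), a step that starts from compound 2, whose entry is a limit and not a number: the limit of > 100000 nM in this assay, at which 1 of the 4 values shown sits.

Going by these compounds, whether a still longer chain, an amine at the end of the chain, or a plain phenyl would come closer to compound 1 stays open.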